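Returning the methyl and swapping the ring in compound 3

The compounds below may be only part of what the source reports. "The series", "measured", "known", "first", "only" and "open" are said of these compounds alone.

Of the compounds shown here, two have been measured in an assay on CHO cells with 5-hydroxytryptamine receptor 1D (Homo sapiens) as the target; on this read-out higher numbers stand for weaker inhibition and lower numbers for stronger inhibition. Compound 1 `CN(Cc1ccccc1)CC1(O)CCN(CCCc2c[nH]c3ccc(-n4cnnc4)cc23)CC1` gives 1.2 nM. Compound 2 `CC(=O)Nc1ccc(CNCC2(O)CCN(CCCc3c[nH]c4ccc(-n5cnnc5)cc34)CC2)cc1` gives 11 nM, the higher of the two numbers, reached by a step of a 9.2-fold higher number from compound 1 to compound 2 (0.96 log units; beyond the scatter) when (4-acetamidobenzyl)amino took the place of benzyl(methyl)amino on a saturated chain carbon bound to a saturated ring carbon. Compound 3 `CN(CC1CCCCC1)CC1(O)CCN(CCCc2c[nH]c3ccc(-n4cnnc4)cc23)CC1` differs from compound 2 by (cyclohexylmethyl)(methyl)amino in place of (4-acetamidobenzyl)amino on a saturated chain carbon bound to a saturated ring carbon. Within the data shown here, this change puts the methyl back on the amine nitrogen and removes the acetamide, undoing much of what separated compound 1 from compound 2, while the six-membered aromatic ring becomes a non-aromatic one, a swap that no measured step covers. Compound 1, carrying benzyl(methyl)amino, gave 1.2 nM. On that basis the step is expected to be a 4.4-fold lower number from compound 2 to compound 3 (0.64 log units; beyond the scatter), towards a lower number. Compound 3 is therefore estimated at 2.5 nM, with a range from 0.6 nM to 10 nM.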

Compound 3, half-maximal inhibitory concentration: 1.2 nM
Estimate against measurement, compound 3: 2.1-fold (0.32 log units) above; low and high end bracket the measured number.
By their numbers in this assay, from the lowest: compounds 1 and 3 (each within the scatter of the next); then compound 2.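

In this assay, cyclohexyl in place of phenyl gives no change at the digits printed from compound 1 to compound 3 (within the scatter), so at this place the six-membered ring can be aromatic or non-aromatic with no change beyond the scatter. Among these compounds, the wider replacement of (4-acetamidobenzyl)amino by (cyclohexylmethyl)(methyl)amino gives a 9.2-fold lower number from compound 2 to compound 3 (0.96 log units; beyond the scatter), which cancels the rise seen on going from the first compound of the series to compound 2. No measurement here bears on why these numbers fall as they do.

Whether the higher number of compound 2 goes with the acetamide or with the absent methyl on the amine nitrogen stays open, since the two change together in every step shown. Also open, going by these compounds, is how a cyclopentyl ring or a pyridine ring would read at this place in this assay.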